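A few compounds are considered here, and "the series" means these few. Any claim that something is new, unique, unknown or untested is made for them only; others in the source may bear on it.

Compound 1 is `O=C(O)/C(S)=C/c1ccccc1Br`. Within the data shown here, in an assay on isolated protein for inhibition of Calpain-1 catalytic subunit (Sus scrofa), read by FRET (on this read-out lower numbers stand for stronger inhibition and higher numbers for weaker inhibition), compound 1 gives 21000 nM, the highest of the two numbers measured so far. Compound 2 is `O=C(O)/C(S)=C/c1c[nH]c2cc(F)ccc12`, and in this assay compound 2 gives 10 nM, a much lower number. Among the measured compounds shown here, no step between two measured compounds that differ in one place is available. Compound 3 is `O=C(O)/C(S)=C/c1ccccc1F`; it differs from compound 1 by fluoro in place of bromo on an aromatic carbon. For the measured compounds named here, nothing among the measured compounds shows the size of this change, so the step of a 1.2-fold higher number from compound 1 to compound 3 (0.08 log units; within the scatter) is expected to be small, in either direction, and within the scatter. Compound 3 is estimated at 25000 nM, with a range from 8000 nM to 80000 nM.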

Compound 3, half-maximal inhibitory concentration: 21900 nM
For compound 3 the middle estimate is 1.1-fold (0.06 log units) above the measured one; measured number inside the range.
By their numbers in this assay, from the lowest: compound 2; then compounds 1 and 3 (each within the scatter of the next).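

In this assay, putting fluoro in place of bromo on an aromatic carbon, ortho to a group of 6 heavy atoms, gives a 1.0-fold higher number from compound 1 to compound 3 (0.02 log units; within the scatter) as the size of this change. At this position, then, these two halogens cannot be told apart on this read-out. Nothing measured here explains why the two compounds read alike.

The compounds shown leave open what a group other than a halogen, such as an amine, a methoxy group or a carboxylic acid, would do at this position. They also leave open whether the same exchange would be as small on the core of compound 2.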